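This account rests on a few compounds, and the source may have more. Where it says the series, first, only, none or still open, it means among the compounds named here.

Measured compounds:
- compound 1 `Fc1ccc(C2=CC3CNCC(C2)C3)cn1`: 85 nM
- compound 2 `C1=C(c2cncnc2)CC2CNCC1C2`: 240 nM
- compound 3 `CN1CC2C=C(c3ccc(F)nc3)CC(C2)C1`: > 10000 nM

In an in vitro functional assay on SH-EP1 cells for agonist activity at Neuronal acetylcholine receptor; alpha4/beta2 (Homo sapiens), read by FLIPR and calcium flux (on this read-out lower numbers stand for an effect already at smaller amounts and higher numbers for an effect only at larger amounts of compound), compound 1 gives 85 nM. Compound 2 gives 240 nM in this assay. For compound 3 only a limit is known, > 10000 nM; this value sits at the limit of > 10000 nM in this assay, at which 1 of the 3 values shown sits. Compound 3 thus stands at the edge of what this assay reports, with no number of its own. For the measured compounds named here, the one measured step that reaches compound 3 is an at least 110-fold higher number from compound 1 to compound 3 (2.07 log units; beyond the scatter), and it is large.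

Compound 4 `COc1ccc(C2=CC3CC(C2)CN(C)C3)cn1` differs from compound 3 by methoxy in place of fluoro on an aromatic carbon. Going by the values given here, none of the measured steps concerns a change of this kind; the only measured step, from compound 1 to compound 3, concerns the methyl on the amine nitrogen, which compound 4 keeps. With that methyl retained, compound 4 is expected to remain at or near the limit in this assay, the step that the limit leaves unreadable from compound 3 to compound 4 being an estimate without a measured counterpart. The expected value for compound 4 is 15000 nM, in the range 3000 nM to 60000 nM.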

Compound 4, half-maximal effective concentration: 3460 nM
Beside the measured number, compound 4's estimate is 4.3-fold (0.64 log units) above it; measured number inside the range.
By their numbers in this assay, from the lowest: compound 1; then compound 2; then compound 4. At a limit, above all of these: compound 3.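

In this assay the change to methoxy in place of fluoro next to the ring nitrogen, with the methyl on the amine nitrogen kept, gives an at least 2.8-fold lower number from compound 3 to compound 4 (0.46 log units; beyond the scatter) and brings the series from a limit to a measured number. For the compounds shown here, this aromatic position therefore also moves the read-out, whereas the only earlier step concerned the amine nitrogen. Compound 3 carries only a limit, > 10000 nM and no number of its own, so the size of this step is only a lower bound: the limit of > 10000 nM in this assay, at which 1 of the 4 values shown sits.

Open, from the compounds shown here alone, is how methoxy reads with hydrogen in place of the methyl on the amine nitrogen, and so whether the two changes act independently. Also open, going by these compounds, is how an amine or a longer ether such as ethoxy would read at this aromatic carbon.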